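Swapping a methyl for hydrogen on compound 1

The compounds below may be only part of what the source reports. "The series", "measured", "known", "first", "only" and "open" are said of these compounds alone.

In an ADME assay on liver for metabolic stability, with Liver microsome (Homo sapiens) as the target, read by LC-MS, using microsomes, with a stated time of 5 h (on this read-out higher numbers stand for fast clearance and lower numbers for slow clearance), compound 1 `C[C@]1(O)C[C@](c2ccnc(C(F)(F)F)c2)([C@H](O)c2ccccn2)C1` gives 66.7 mL/min/kg. Compound 2 `O[C@@]1(c2ccccn2)CC[C@H](c2ccc(C(F)(F)F)cc2)C1` gives 400 mL/min/kg. Within the data shown here, the gap between these two values lies beyond the usual scatter of repeated measurements, so compound 1 holds the lower of the only two numbers available.

Compound 3 `O[C@H](c1ccccn1)[C@]1(c2ccnc(C(F)(F)F)c2)C[C@H](O)C1` has not yet been measured. It keeps the core of compound 1 and carries a single edit: hydrogen in place of methyl on a saturated ring carbon. In words, this is hydrogen in place of methyl on a saturated ring carbon, and that carbon belongs to a four-membered non-aromatic ring of carbon only.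

Among the measured compounds shown here, no two measured compounds differ in just one place, so the data offer no direct guide to this edit and any forecast stays loose. The natural anchor is compound 1 at 66.7 mL/min/kg. The estimated step of a 1.2-fold lower number from compound 1 to compound 3 (0.08 log units; within the scatter) is small, and no change beyond the scatter is expected in either direction. For compound 3 the expected value is 55 mL/min/kg, with an estimated range from 25 mL/min/kg to 120 mL/min/kg.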

Compound 3, clearance: 33.3 mL/min/kg
Compound 3: middle estimate off by 1.7-fold (0.22 log units), on the high side, and the stated range covers the measured number.
By their numbers in this assay, from the lowest: compounds 3 and 1 (each within the scatter of the next); then compound 2.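

Among these compounds, this is the first change in the set confined to one place, so the methyl on this saturated ring carbon of the four-membered ring can now be judged on its own. In this assay the swap to hydrogen gives a 2.0-fold lower number from compound 1 to compound 3 (0.30 log units; within the scatter) and so the clearance of the two compounds cannot be told apart, which means that at this position the methyl and the hydrogen give results that repeated measurements would not separate. Nothing available here explains this result, and the pair alone offers no reason for it.

Only methyl and hydrogen appear at this ring carbon, so the compounds shown leave open what an ethyl group, a fluorine atom or an amine would do in the same place, and whether any such group would move clearance beyond the usual scatter. They also leave open whether the same swap would give a similar result on a different core, since this single pair speaks only for the core of compound 1.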